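A few compounds are considered here, and "the series" means these few. Any claim that something is new, unique, unknown or untested is made for them only; others in the source may bear on it.

Compound 1 `O=C(CCc1nc2ccccc2c(=O)[nH]1)N/N=C/c1ccc(O)cc1` (300000000 nM)
Compound 2 `O=C(CCCc1nc2ccccc2c(=O)[nH]1)N/N=C/c1cc(O)c(O)c(O)c1` (45000000 nM)
Compound 3 `COc1cc(/C=N/NC(=O)CCc2nc3ccccc3c(=O)[nH]2)cc(OC)c1OC` (80000000 nM)

In a physicochemical assay, read by spectrophotometry, with a stated time of 15 min (on this read-out higher numbers stand for weaker inhibition and lower numbers for stronger inhibition), compound 2 (45000000 nM) lies within the scatter of compound 3 (80000000 nM), while its number is lower, beyond the scatter, than that of compound 1 (300000000 nM). Compound 4 `COc1cc(/C=N/NC(=O)CCCc2nc3ccccc3c(=O)[nH]2)cc(O)c1O`, not yet measured, carries, relative to compound 2, methyl in place of hydrogen on an oxygen on an aromatic ring. Among the compounds with values here, no measured pair shows this change alone. In this assay no step beyond the scatter is expected, an expectation resting only on the closeness of compound 3 (80000000 nM) to compound 2 (45000000 nM). The estimated step is small (a 1.3-fold higher number from compound 2 to compound 4 (0.12 log units; within the scatter)). For compound 4 the expected value is 60000000 nM (estimated range 25000000 nM to 150000000 nM).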

Compound 4, half-maximal inhibitory concentration: 80000000 nM
Compound 4: the middle estimate sits 1.3-fold (0.12 log units) below what was measured; the range from low to high includes it.
By their numbers in this assay, from the lowest: compounds 2, 3 and 4 (each within the scatter of the next); then compound 1.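

Compound 2 and compound 4 form the first pair differing in one place, and in this assay hydroxy to methoxy on an oxygen on an aromatic ring gives a 1.8-fold higher number from compound 2 to compound 4 (0.25 log units; within the scatter), so the two cannot be told apart on this read-out. Methyl in place of hydrogen at this place therefore leaves the number within the scatter. Nothing available explains this result. The compounds shown leave open whether ethyl or a longer chain on this oxygen would also stay within the scatter of compound 2. They also leave open how an amine or a carboxylic acid at this place would read.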